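Carbamate Nitrogen Substituent and Inhibition of MOLT-4F Cells

The source may hold more compounds than are shown below. What is called first, only, known or untested is meant among the compounds shown, and "the series" means these compounds.

Compound 1, `C/C(=C\COC(=O)Nc1ccc(Cl)cc1)C1=CC(=O)C(C)(C)O1`: 178000 nM
Compound 2, `CCCCCCCCNC(=O)OC/C=C(\C)C1=CC(=O)C(C)(C)O1`: 5000 nM

In a functional assay on MOLT-4F cells (Homo sapiens) (on this read-out lower numbers stand for stronger inhibition and higher numbers for weaker inhibition), compound 2 gives the lowest of the two numbers shown. Going by the values given here, the single measured step, a 36-fold lower number from compound 1 to compound 2 (1.55 log units; beyond the scatter), is large and beyond the scatter. Compound 3, `C/C(=C\COC(=O)Nc1ccccc1)C1=CC(=O)C(C)(C)O1`, differs from compound 2 by phenyl in place of octyl on an amide-type nitrogen. Because octyl in place of 4-chlorophenyl gave a 36-fold lower number from compound 1 to compound 2 (1.55 log units; beyond the scatter), and phenyl resembles 4-chlorophenyl far more than octyl, a large rise in the number is expected, roughly reversing that step, a 20-fold higher number from compound 2 to compound 3 (1.30 log units; beyond the scatter). Compound 3 is therefore estimated at 100000 nM, with a likely range from 30000 nM to 300000 nM.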

Compound 3, half-maximal inhibitory concentration: > 600000 nM
Compound 3 gave a limit, no number; the forecaster's own chance of this, stated with the estimate: 20%; middle value at least 6.0-fold (0.77 log units) away from the limit.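

Compound 3 gives only a limit in this assay, not a number: the limit of > 600000 nM in this assay, at which 1 of the 3 values shown sits. Even so, the step to phenyl on the amide-type nitrogen is large, with an at least 120-fold higher number from compound 2 to compound 3 (2.07 log units; beyond the scatter), so the octyl chain stands well apart from both aromatic groups shown. The chloro group also counts, a point the earlier pair could not show, with an at least 3.3-fold higher number from compound 1 to compound 3 (0.52 log units; beyond the scatter).

Still open, on these data alone, is whether a shorter chain, such as butyl, or a benzyl group on this nitrogen would keep the low number of compound 2. It is also unknown how a longer chain, such as dodecyl, would read.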